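Swapping a pyridine for an oxazole on a urea

The source may report more compounds than this note shows. Statements on the series, on what has been measured and on what is new or still open speak of the compounds shown alone.

Compound 1 `O=C(Nc1ccc(F)c(C(F)(F)F)c1)Nc1ccccn1` is a urea that carries a pyridin-2-yl group on one nitrogen. Among the measured compounds shown here, in an ADME assay on microsomes from liver (Homo sapiens) for metabolic stability, using NADPH, with a stated time of 60 min (on this read-out higher numbers stand for fast clearance and lower numbers for slow clearance), compound 1 gives 188 uL/min, the only outright number among the three measured compounds. Compound 2 `N#Cc1ccc(NC(=O)Nc2ccc(F)c(C(F)(F)F)c2)cc1` carries a nitrile-bearing phenyl ring in the same place. In this assay compound 2 is reported only as a limit of the assay, < 7 uL/min. Compound 3 `O=C(Nc1ccnc(C(F)(F)F)c1)Nc1ccc(F)c(C(F)(F)F)c1` carries a pyridin-4-yl ring bearing a trifluoromethyl group. In this assay compound 3 is likewise reported as a limit, < 7 uL/min. Compound 1 therefore stands at the fast end of what has been seen, since the limit of < 7 uL/min in this assay, at which 2 of the 3 values shown sit, describes where the other two sit.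

Compound 4 `Cc1cc(NC(=O)Nc2ccc(F)c(C(F)(F)F)c2)on1` has not been measured yet. It differs from compound 1 by 3-methyl-1,2-oxazol-5-yl in place of pyridin-2-yl on an amide-type nitrogen. For the measured compounds named here, no step between measured compounds matches this change, so no directly comparable step is available, and only the three values above can guide a guess. Because two of three compounds sit at the limit of < 7 uL/min in this assay, at which 2 of the 3 values shown sit, a move toward slower clearance seems the more likely direction. The expected step from compound 1 to compound 4 in this assay is a 4.7-fold lower number from compound 1 to compound 4 (0.67 log units; beyond the scatter). Compound 4 is estimated at 40 uL/min, with a range from 7 uL/min to 150 uL/min.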

Compound 4, intrinsic clearance in a liver preparation (reported as CLH), per the amount of preparation that the assay uses in the Homo sapiens assay: 73 uL/min
Compound 4: middle estimate off by 1.8-fold (0.26 log units), on the low side; low and high end bracket the measured number.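

Among the compounds shown here, this is the first outright number on the amide-type nitrogen other than that of compound 1: in the Homo sapiens assay, 3-methyl-1,2-oxazol-5-yl in place of pyridin-2-yl gives a 2.6-fold lower number from compound 1 to compound 4 (0.41 log units; beyond the scatter), a modest move toward slower clearance. The same change also shifts lipophilicity, since in a physicochemical assay for lipophilicity, read by HPLC, measured as octanol-water partition, at pH 7.2 (a higher number here means a more lipophilic compound, a lower number a more polar compound), compound 1 gives 3.7 and compound 4 gives 3.2, so both read-outs fall together for this pair. Compound 2 and compound 3 are each reported only as a limit of the assay, not as a number, and compound 4 keeps a measurable clearance rather than joining them: the limit of < 7 uL/min in the Homo sapiens assay, at which 2 of the 4 values shown sit.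

This single pair moves both read-outs at once, so it cannot separate any link between clearance and the distribution coefficient from an effect of the ring swap itself. The compounds shown also do not tell what the methyl group contributes, or how a 1,2-oxazol-5-yl ring carrying an amine or a carboxylic acid in its place would behave in either assay.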